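The source may hold more compounds than are shown below. What is called first, only, known or untested is meant among the compounds shown, and "the series" means these compounds.

Compound 1, with the structure `Cc1cc2c(c(N)nn2C)c(=O)[nH]1`, was tested in an assay on isolated protein for inhibition of serine/threonine-protein kinase Chk2 (Homo sapiens), read by mobility shift assay, tested at 30 uM (on this read-out lower numbers stand for less inhibition and higher numbers for more inhibition at the one concentration tested (going by the name of the read-out)), where compound 1 gives 3%. Compound 2, with the structure `Cc1cc2c(c(N)nn2C)c(N2CC[C@H](O)C2)n1`, was tested in the same way, and in this assay compound 2 gives -2%. Among the measured compounds shown here, of the two numbers so far, compound 2 stands together with compound 1, the gap between them lying within the usual scatter of this kind of measurement, so neither can be said to inhibit more than the other. Compound 3, with the structure `Cc1cc2c(cn1)c(N)nn2C`, differs from compound 2 in one place: hydrogen in place of 3-hydroxypyrrolidin-1-yl on an aromatic carbon. Since the two measured compounds show no difference beyond the scatter, the expected step from compound 2 to compound 3 in this assay is a number 3 percentage points higher from compound 2 to compound 3 (within the scatter), that is, no change beyond the scatter. Compound 3 is accordingly estimated to give 1% in this assay, within a range from -10% to 12%.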

Compound 3, a percentage reported as inhibition, at one concentration (the size of the read-out at that concentration, not a potency): 3%
Estimate against measurement, compound 3: 2 percentage points below; measured number inside the range.
By their numbers in this assay, from the lowest: compounds 2, 1 and 3 (each within the scatter of the next).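

In this assay, hydrogen in place of 3-hydroxypyrrolidin-1-yl on an aromatic carbon next to the ring nitrogen gives a number 5 percentage points higher from compound 2 to compound 3 (within the scatter), so this exchange does not separate the two compounds. With either the whole 3-hydroxypyrrolidin-1-yl group or only hydrogen on this carbon, the read-out at the one concentration tested stays within the scatter, and the group's ring, hydroxyl and defined stereocentre show no effect that can be read here. Nothing available explains this result. The compounds shown leave open whether another group on this carbon, such as a primary amine or a carboxylic acid, would give a number beyond the scatter. They also leave open whether a longer chain ending in a dimethylamino group would do so.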